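This account rests on a few compounds, and the source may have more. Where it says the series, first, only, none or still open, it means among the compounds named here.

Measured so far in a functional assay on MCF7 cells (Homo sapiens) for cytotoxicity, read by MTT assay, with a stated time of 72 h; a lower number here means a stronger inhibitor, a higher number a weaker inhibitor:

compound 1, `CNC(=O)c1cc(Oc2ccc(C(=O)/C=C/c3cc(OC)c(OC)c(OC)c3)cc2)ccn1`: 3880 nM
compound 2, `CNC(=O)c1cc(Oc2ccc(/C=C/C(=O)c3ccc(C)cc3)cc2)ccn1`: 24900 nM
compound 3, `CNC(=O)c1cc(Oc2ccc(C(=O)/C=C/c3cccc(Br)c3)cc2)ccn1`: 10400 nM

Compound 3 stands second highest of the three numbers in this assay. Its nearest neighbour is compound 2, whose value of 24900 nM lies higher by a gap beyond the scatter. Furthest from it is compound 1, whose value of 3880 nM lies lower, again by a gap beyond the scatter. Compound 1 and compound 2 each differ from compound 3 in more than one place, so their values show only where the three stand, and no single change can be read from them.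

Compound 4, `CNC(=O)c1cc(Oc2ccc(C(=O)/C=C/c3ccc(Cl)c(Cl)c3)cc2)ccn1`, has not yet been measured in this assay. It differs from compound 3 in one place: 3,4-dichlorophenyl in place of 3-bromophenyl on a double-bonded chain carbon bound to a double-bonded chain carbon. For the measured compounds named here, no measured pair tracks this change, so there is no step to lean on. A halogenated phenyl remains on the double-bonded chain carbon, and the rest of the core of compound 3 is kept.

Compound 4 is expected at 9000 nM in this assay, with a range from 3500 nM to 25000 nM. The expected step from compound 3 to compound 4, a 1.2-fold lower number from compound 3 to compound 4 (0.06 log units; within the scatter), is estimated to stay within the scatter, with no clear direction.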

Compound 4, half-maximal inhibitory concentration: 13200 nM
Estimate against measurement, compound 4: 1.5-fold (0.17 log units) below; the measured number falls inside the stated range.
By their numbers in this assay, from the lowest: compound 1; then compounds 3, 4 and 2 (each within the scatter of the next, the first and the last beyond it).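

In this assay this position now has its first comparison that differs in one place: on a double-bonded chain carbon bound to a double-bonded chain carbon, 3,4-dichlorophenyl in place of 3-bromophenyl gives a 1.3-fold higher number from compound 3 to compound 4 (0.10 log units; within the scatter) and so stays within the scatter. The single bromine and the two chlorines are therefore not told apart in this assay, and the added heavy atom in the entering group brings no readable change, so this one exchange gives no direction for the series. No supporting measurement is available that bears on this result.

Still open, going by these compounds, is how far this position holds the value when the halogenated phenyl is replaced by something else, such as an unsubstituted phenyl, an aminophenyl or a carboxyphenyl, since one exchange between two halogenated phenyl groups cannot show that. Also open is how much of the spread among the compounds shown comes from this group rather than from other parts of the structure, as no one-place pair links compound 3 or compound 4 to compound 1 or compound 2.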